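The source may hold more compounds than are shown below. What is called first, only, known or untested is meant among the compounds shown, and "the series" means these compounds.

Measured so far:
Compound 1, `O=C(Nc1cccc(-n2cc(-c3ccncc3)c(-c3ccc(Cl)c(O)c3)n2)c1)Nc1cccc(C(F)(F)F)c1`, gives 29000 nM in a functional assay on NCI-H460 cells (Homo sapiens) for inhibition, read by sulforhodamine B assay, with a stated time of 48 h; on this read-out higher numbers stand for weaker inhibition of growth and lower numbers for stronger inhibition of growth.
Compound 2, `COc1cc(-c2nn(-c3cccc(NC(=O)Nc4ccc(Cl)c(Cl)c4)c3)cc2-c2ccncc2)ccc1Cl`, gives > 50000 nM in this assay.

For compound 2 the value is a limit of the assay and not a number; it sits at the limit of > 50000 nM in this assay, at which 1 of the 2 values shown sits. Compound 1 carries a 4-chloro-3-hydroxyphenyl group and inhibits growth only weakly, while compound 2 carries a 4-chloro-3-methoxyphenyl group and reaches no measurable value at all.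

Compound 3, `O=C(Nc1cccc(-n2cc(-c3ccncc3)c(-c3ccc(Cl)c(O)c3)n2)c1)Nc1ccc(Cl)c(Cl)c1`, has not yet been measured. It differs from compound 2 in one place: hydrogen in place of methyl on an oxygen on an aromatic ring. Compound 2 shows only a limit, and the step from compound 2 to compound 3 cannot be sized from the numbers shown; any change within the scatter or a modest gain in growth inhibition seems plausible, and a value near that of compound 1 would fit. Compound 3 is therefore estimated at 35000 nM, within 12000 nM to 100000 nM, which means an expected step of an at least 1.4-fold lower number from compound 2 to compound 3 (0.15 log units; that floor lies within the scatter).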

Compound 3, concentration for total growth inhibition: 3570 nM
The estimate for compound 3 lay 9.8-fold (0.99 log units) above the measured number; the measured number lies below the stated range.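

In this assay compound 2 stands at a limit of the assay and not at a number: the limit of > 50000 nM in this assay, at which 1 of the 3 values shown sits. Even so, changing methoxy to hydroxy on the 4-chloro-3-methoxyphenyl group gives an at least 14-fold lower number from compound 2 to compound 3 (1.14 log units; beyond the scatter), so the methyl on this oxygen matters far beyond the usual scatter when the 3,4-dichlorophenyl group is present. With the hydroxy kept, the other end of the molecule also counts: 3,4-dichlorophenyl in place of 3-(trifluoromethyl)phenyl on an amide-type nitrogen gives an 8.1-fold lower number from compound 1 to compound 3 (0.91 log units; beyond the scatter).

As far as these compounds go, it remains open whether another group in place of the hydroxy, such as an amine or an ethoxy, would give similar growth inhibition. From the compounds shown here alone, it is also open how large the methoxy to hydroxy step would be with the 3-(trifluoromethyl)phenyl group of compound 1.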